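Removing both bromo groups: compound 3 to compound 4

The source may report more compounds than this note shows. Statements on the series, on what has been measured and on what is new or still open speak of the compounds shown alone.

In a functional assay on HepG2 cells (Homo sapiens) for cytotoxicity, read by MTT assay, with a stated time of 72 h (a higher number here means a weaker inhibitor, a lower number a stronger inhibitor), compound 1 `COc1cc2ncnc(Nc3ccc(F)c(Cl)c3)c2cc1NC(=O)N/N=C/c1cc(OC)c(OC)c(OC)c1` gives 30100 nM, compound 2 `COc1cc2ncnc(Nc3ccc(F)c(Cl)c3)c2cc1NC(=O)N/N=C/c1ccc(O)c(Br)c1` gives 23800 nM and compound 3 `COc1cc2ncnc(Nc3ccc(F)c(Cl)c3)c2cc1NC(=O)N/N=C/c1cc(Br)c(O)c(Br)c1` gives 36800 nM. Compound 3 therefore stands level with the other two, since all three numbers lie within the scatter of one another.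

Compound 4 `COc1cc2ncnc(Nc3ccc(F)c(Cl)c3)c2cc1NC(=O)N/N=C/c1ccc(O)cc1` is the next structure, with 4-hydroxyphenyl in place of 3,5-dibromo-4-hydroxyphenyl on a carbon with a double bond to nitrogen.

The closest measured change is bromo in place of hydrogen on an aromatic carbon, which gave a 1.5-fold higher number from compound 2 to compound 3 (0.19 log units; within the scatter). Replacing 3,4,5-trimethoxyphenyl also produced only small steps: a 1.3-fold lower number from compound 1 to compound 2 (0.10 log units; within the scatter) and a 1.2-fold higher number from compound 1 to compound 3 (0.09 log units; within the scatter). Within the data shown here, no measured compound carries the 4-hydroxyphenyl group itself, so this remains an extrapolation. All three measured steps are small, so no step beyond the scatter is expected in this assay. The expected step is a 1.3-fold lower number from compound 3 to compound 4 (0.12 log units; within the scatter). Compound 4 is estimated at 28000 nM, with an expected range from 14000 nM to 55000 nM.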

Compound 4, half-maximal inhibitory concentration: 26300 nM
For compound 4 the middle estimate is 1.1-fold (0.03 log units) above the measured one; the measured number falls inside the stated range.
By their numbers in this assay, from the lowest: compounds 2, 4, 1 and 3 (each within the scatter of the next).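

In this assay, among these compounds, removing both bromo groups from the 3,5-dibromo-4-hydroxyphenyl group gives a step within the scatter (a 1.4-fold lower number from compound 3 to compound 4 (0.15 log units; within the scatter)), and removing the single bromo group gives the same kind of result (a 1.1-fold higher number from compound 2 to compound 4 (0.04 log units; within the scatter)), so two, one or no bromo groups on this group cannot be told apart. The unsubstituted 4-hydroxyphenyl group also stands level with 3,4,5-trimethoxyphenyl (a 1.1-fold lower number from compound 1 to compound 4 (0.06 log units; within the scatter)), which leaves all four groups on this carbon with a double bond to nitrogen within the scatter of one another. No available evidence helps to interpret this flat result.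

On these data alone, all four compounds carry a six-membered aromatic ring of carbon only at this place, so it remains open whether an amine, a carboxylic acid or a longer alkyl chain in place of that ring would give a step beyond the scatter. As far as these compounds go, whether the same flat result holds outside this one cell assay also remains open.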